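This account rests on a few compounds, and the source may have more. Where it says the series, first, only, none or still open, it means among the compounds named here.

Compound 1 `Cn1cc(-c2cnc(NCc3c(F)ccc4c3CCO4)c3cn[nH]c(=O)c23)cn1` has the lower of the two numbers recorded in a physicochemical assay for solubility, read by LC-MS, in phosphate buffer, with a stated time of 24 h, at pH 7.4; a higher number here means a more soluble compound, a lower number a less soluble compound: compound 1 gives 1000 nM, and compound 3 `CN(C)Cc1ccc2c(c1)CN(c1cnc(NCc3c(F)ccc4c3CCO4)c3cn[nH]c(=O)c13)C2=O` gives 174000 nM, a gap beyond the usual scatter. For compound 2 `CN(c1ccccc1)c1cnc(NCc2c(F)ccc3c2CCO3)n2cnnc12` this assay records only a limit, < 2000 nM, which is the limit of < 2000 nM in this assay, at which 1 of the 3 values shown sits.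

Compound 4 `Cc1nn(C)cc1-c1cnc(NCc2c(F)ccc3c2CCO3)c2cn[nH]c(=O)c12` differs from compound 1 in a single place: methyl in place of hydrogen on an aromatic carbon. Within the data shown here, no pair of measured compounds shows this kind of step, so its size cannot be read from the data. A methyl in place of hydrogen is a small change, and compound 4 is expected to land near compound 1 in this assay, the step of a 1.3-fold lower number from compound 1 to compound 4 (0.10 log units; within the scatter) most likely within the scatter or a slight drop. Compound 4 is therefore estimated at 800 nM, with a range of 300 nM to 2500 nM.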

Compound 4, solubility: 9000 nM
Beside the measured number, compound 4's estimate is 11-fold (1.05 log units) below it; the measured number lies above the stated range.
By their numbers in this assay, from the lowest: compound 1; then compound 4; then compound 3.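

At this aromatic carbon, next to the ring nitrogen, the change from 1-methyl-1H-pyrazol-4-yl to 1,3-dimethyl-1H-pyrazol-4-yl gives a 9.0-fold higher number from compound 1 to compound 4 (0.95 log units; beyond the scatter) in this assay. A single added heavy atom, with no hydrogen-bond donors or acceptors and no net charge, is thus enough at this place to raise the number beyond the scatter. Nothing measured here bears on why the number rises. On these data alone, whether an ethyl, a methoxy or an amine on the same carbon would raise the number further or bring it back stays open.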